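From benzyloxycarbonyl to carbamoyl on the shared core

The source may hold more compounds than are shown below. What is called first, only, known or untested is meant among the compounds shown, and "the series" means these compounds.

In a functional assay on SEM cells (Homo sapiens) for cytotoxicity, with a stated time of 72 h (a higher number here means that more compound is needed for the effect, a lower number that less compound is needed), compound 1 `C=C[C@@](C)(/C=C/c1ccc(O)c(C=O)c1)CCC=C(C)C` gives 8510 nM. Compound 2 `C=C[C@@](C)(/C=C/c1ccc(O)c(/C=C/C(=O)OCC)c1)CCC=C(C)C` reaches only a limit, > 36600 nM. Compound 3 `C=C[C@@](C)(/C=C/c1ccc(O)c(/C=C/C(=O)OCc2ccccc2)c1)CCC=C(C)C` also reaches only a limit, > 36600 nM. Putting 2-(ethoxycarbonyl)ethenyl in place of formyl gave an at least 4.3-fold higher number from compound 1 to compound 2 (0.63 log units; beyond the scatter), and phenyl in place of methyl on a saturated chain carbon gave a step that the two limits leave unreadable from compound 2 to compound 3. Compound 4 `C=C[C@@](C)(/C=C/c1ccc(O)c(/C=C/C(N)=O)c1)CCC=C(C)C` has amino in place of benzyloxy on a carbonyl carbon. Neither step tests this swap directly, but compound 4 keeps the ethenyl chain that entered in an at least 4.3-fold higher number from compound 1 to compound 2 (0.63 log units; beyond the scatter), so little change is expected. The expected step is small, an at least 1.2-fold lower number from compound 3 to compound 4 (0.08 log units; that floor lies within the scatter), towards a slightly lower number if any. The estimate for compound 4 is 30000 nM, with an expected range of 12000 nM to 60000 nM.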

Compound 4, half-maximal effective concentration: > 36600 nM
Compound 4: a limit, no number (the forecaster's own chance of this, stated with the estimate: 55%); middle value at least 1.2-fold (0.08 log units) away from the limit.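

Compound 4 gives > 36600 nM in this assay as a limit, not a number. Putting 2-carbamoylethenyl in place of formyl gave an at least 4.3-fold higher number from compound 1 to compound 4 (0.63 log units; beyond the scatter) and so, at this position, a carbamoyl end goes with a higher number just as the two ester ends do. The steps among compound 2, compound 3 and compound 4 cannot be read: the limit of > 36600 nM in this assay, at which 3 of the 4 values shown sit.

From the compounds shown here alone, whether these three compounds differ from one another stays open. Also open, going by these compounds, is what a carboxylic acid at the end of the ethenyl chain would give.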